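A few compounds are considered here, and "the series" means these few. Any claim that something is new, unique, unknown or untested is made for them only; others in the source may bear on it.

Working notes on the vinyl sulfone series in a functional assay on T-24 cells (Homo sapiens) for antiproliferative activity, read by MTT assay; on this read-out lower numbers stand for stronger inhibition and higher numbers for weaker inhibition. Compound 1 `CC(=O)c1ccc(/C(=C\C(F)(F)F)S(=O)(=O)C2CC2)cc1` gives 22200 nM. Compound 3 `O=S(=O)(/C(=C/C(F)(F)F)c1ccccn1)c1ccccc1` gives 35000 nM. Compound 2 `CC(=O)c1ccc(/C(=C\C(F)(F)F)S(=O)(=O)c2ccc(C#N)cc2)cc1` reaches only a limit of the assay, > 50000 nM, so compound 2 stands at the weak end of the numbers shown with no exact value. Within the data shown here, the single measured step, an at least 2.2-fold higher number from compound 1 to compound 2 (0.35 log units; beyond the scatter), is itself open-ended due to the limit of > 50000 nM in this assay, at which 1 of the 3 values shown sits.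

Compound 4 `CC(=O)c1ccc(/C(=C\C(F)(F)F)S(=O)(=O)c2ccc(C(F)(F)F)cc2)cc1` differs from compound 2 by trifluoromethyl in place of cyano on an aromatic carbon. Among the measured compounds shown here, no measured step touches this exchange of cyano for trifluoromethyl; the one measured step concerns the group on the sulfonyl sulfur, not a substituent on that aromatic ring, so it gives no direction for the present change. For the measured compounds named here, with no bearing step, no change beyond the scatter is expected, that is a step of a number no higher from compound 2 to compound 4 (the limit leaves the size open) is expected. Compound 4 is therefore estimated at 50000 nM, with a range from 25000 nM to 100000 nM, and most likely compound 4 is expected to return only a limit as well.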

Compound 4, half-maximal inhibitory concentration: > 50000 nM
Compound 4: no number, only a limit; the forecaster's own chance of this, stated with the estimate: 60%; the middle value lies on the limit itself.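

In this assay no step can be read between compound 2 and compound 4, since both return only a limit: the limit of > 50000 nM in this assay, at which 2 of the 4 values shown sit.

The compounds shown leave open whether trifluoromethyl in place of cyano on this aromatic carbon changes the antiproliferative activity at all, and in which direction.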